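The compounds below may be only part of what the source reports. "The series", "measured", "known", "first", "only" and "open" are said of these compounds alone.

Measured compounds in an assay for inhibition of Amine oxidase [flavin-containing] A (Rattus norvegicus); on this read-out lower numbers stand for stronger inhibition and higher numbers for weaker inhibition:
- compound 1, `COc1ccc(COc2ccc(-c3nn(CCC#N)c(=S)o3)cc2)cc1`, gives 4800 nM
- compound 2, `Cc1ccc(COc2ccc(-c3nn(CCC#N)c(=S)o3)cc2)cc1`, gives 10000 nM
- compound 3, `COc1cccc(COc2ccc(C3=NN(CCC#N)C(=O)CO3)cc2)c1`, gives 32000 nM

Compound 1 and compound 2 share one core and differ by one change, (methyl in place of methoxy on an aromatic carbon). That change gave a 2.1-fold higher number from compound 1 to compound 2 (0.32 log units; beyond the scatter) in this assay.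

Compound 3 has a different core from compound 1; the difference between the two cores is not broken down here. Compound 3 stands highest of the three numbers measured, beyond the scatter against both compound 1 and compound 2.

Compound 4, `Cc1cccc(COc2ccc(C3=NN(CCC#N)C(=O)CO3)cc2)c1`, is not yet measured. It differs from compound 3 by methyl in place of methoxy on an aromatic carbon. Among the compounds with values here, this is the same kind of change as the one from compound 1 to compound 2, with one difference in its surroundings: in compound 1 to compound 2 the group sits para to a large group, in compound 3 to compound 4 it sits meta to a large group. The cores also differ, so the earlier step is a guide and not a rule.

For compound 4 in this assay a step of a 1.9-fold higher number from compound 3 to compound 4 (0.27 log units; within the scatter) is expected, resting on the step of a 2.1-fold higher number from compound 1 to compound 2 (0.32 log units; beyond the scatter) and on the starting number of compound 3, 32000 nM. The estimate for compound 4 is 60000 nM, expected between 25000 nM and 150000 nM; given the high starting number, a limit rather than a number is a real possibility.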

Compound 4, half-maximal inhibitory concentration: 40000 nM
Estimate against measurement, compound 4: 1.5-fold (0.18 log units) above; the measured number falls inside the stated range.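

In this assay, methyl in place of methoxy on an aromatic carbon gives a 1.3-fold higher number from compound 3 to compound 4 (0.10 log units; within the scatter), and the two steps for this change cannot be told apart: the same change on two cores in this assay, a 2.1-fold higher number (0.32 log units; beyond the scatter) from compound 1 to compound 2 and a 1.3-fold higher number (0.10 log units; within the scatter) from compound 3 to compound 4, 1.7-fold (0.22 log units) apart, within the scatter of two such steps

The change can therefore be carried from the core of compound 1 to the core of compound 3 as a rough guide, with no sign so far that the core alters the size of the step. This does not show that the step is the same on both cores: each core offers a single pair, the place of the group on the ring differs along with the core so the two cannot be separated, and the step on the core of compound 3 lies within the scatter, so that pair alone does not establish any effect of the change.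

Neither core is shown with the group in the place it holds on the other core, so a matched comparison of the two cores remains open. Also open, from the compounds shown here alone, is how far the comparison extends to other groups on that ring, such as a chlorine, a hydroxyl or an amine, and to a carboxylic acid or a longer chain in place of the nitrile-bearing chain.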